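The source may hold more compounds than are shown below. What is called first, only, known or untested is meant among the compounds shown, and "the series" means these compounds.

Compound 1 `CC#CC(CC(=O)O)c1ccc(OCC2COc3ccc(Cl)cc3O2)cc1` and compound 2 `Cn1ccnc1C(CC(=O)O)c1ccc(OCC2COc3ccc(Cl)cc3O2)cc1` share a core and differ only in the group on a saturated chain carbon bound to an aromatic carbon and a saturated chain carbon. In a functional assay on HEK293 cells for agonist activity at Free fatty acid receptor 1 (Homo sapiens), read by fluorescence and calcium flux, with a stated time of 10 min (on this read-out higher numbers stand for larger maximal responses and lower numbers for smaller maximal responses), compound 1 gives 104%, while in this assay compound 2 gives 68%. Within the data shown here, the single measured step, a number 36 percentage points lower from compound 1 to compound 2 (beyond the scatter), therefore leaves compound 2 with the lowest of the two numbers seen so far.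

Compound 3 `Cn1nncc1C(CC(=O)O)c1ccc(OCC2COc3ccc(Cl)cc3O2)cc1` takes the next step from compound 2: 1-methyl-1H-1,2,3-triazol-5-yl in place of 1-methyl-1H-imidazol-2-yl on a saturated chain carbon bound to an aromatic carbon and a saturated chain carbon. Among the measured compounds shown here, no measured step compares two such five-membered aromatic groups against each other, so the only step that bears on it, a number 36 percentage points lower from compound 1 to compound 2 (beyond the scatter), concerns a different exchange. Both groups here are of the same kind, so the step of a number 3 percentage points lower from compound 2 to compound 3 (within the scatter) is expected to stay within the scatter. Compound 3 is accordingly estimated to give about 65%, with a range from 40% to 90%.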

Compound 3, largest response reached (Emax), in percent of the reference or control that the assay uses: 70%
Beside the measured number, compound 3's estimate is 5 percentage points below it, and the stated range covers the measured number.
By their numbers in this assay, from the lowest: compounds 2 and 3 (each within the scatter of the next); then compound 1.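

In this assay the exchange of 1-methyl-1H-imidazol-2-yl for 1-methyl-1H-1,2,3-triazol-5-yl on the saturated chain carbon gives a number 2 percentage points higher from compound 2 to compound 3 (within the scatter) and so makes no difference beyond the scatter, even though the entering ring holds one more nitrogen. Replacing prop-1-yn-1-yl with the triazole gives a number 34 percentage points lower from compound 1 to compound 3 (beyond the scatter) and shows that the large step first seen with the imidazole also occurs with a second five-membered aromatic group. The data shown offer no explanation for either step.

On these data alone, what a propyl chain or a cyclopropyl ring would give at this position remains open, so the compounds do not settle whether the response of compound 1 depends on the triple bond. As far as these compounds go, it is also open whether a thiazol-2-yl or phenyl group would give a response like that of compound 3 or like that of compound 1.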